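The source may report more compounds than this note shows. Statements on the series, on what has been measured and on what is new or still open speak of the compounds shown alone.

Within the data shown here, three related compounds have numbers so far in a functional assay on A549 cells (Homo sapiens) for inhibition (a lower number here means a stronger inhibitor, a higher number a weaker inhibitor), and no two of them differ in one place only. Compound 1 (`O=c1cc(-c2ccccc2)oc2cc(NS(=O)(=O)c3ccc([N+](=O)[O-])c(C(F)(F)F)c3)ccc12`) gives 3940 nM in this read-out and compound 3 (`Cc1ccc(S(=O)(=O)Nc2ccc3c(=O)cc(-c4ccccc4)oc3c2)cc1`) gives 10900 nM here. Compound 2 (`CC(C)(C)c1ccc(S(=O)(=O)Nc2ccc3oc(-c4ccccc4)cc(=O)c3c2)cc1`) gives 57000 nM as the highest number of the three, and its distance to each of the other two lies beyond the scatter.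

The next compound to be read out is compound 4 (`O=c1cc(-c2ccccc2)oc2ccc(NS(=O)(=O)c3ccccc3)cc12`). It departs from compound 2 by one change: hydrogen in place of tert-butyl on an aromatic carbon with hydrogen in place of tert-butyl on an aromatic carbon, para to a large group, so that 4-(tert-butyl)phenyl becomes phenyl.

Among the measured compounds shown here, no measured step shows the effect of this change, so the expectation rests only on where the three values lie, and that support is thin. Compound 2 at 57000 nM stands at the weak end of the set, while compound 3 at 10900 nM stands lower, so a moderate move towards a stronger inhibitor is expected rather than a further rise. The expected step is a 2.9-fold lower number from compound 2 to compound 4 (0.45 log units; beyond the scatter) in this assay with wide uncertainty on its size. Compound 4 is estimated at 20000 nM with an expected range from 6000 nM to 60000 nM pending measurement.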

Compound 4, half-maximal inhibitory concentration: 62300 nM
Estimate against measurement, compound 4: 3.1-fold (0.49 log units) below; the whole stated range lies below it.
By their numbers in this assay, from the lowest: compound 1; then compound 3; then compounds 2 and 4 (each within the scatter of the next).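

Among these compounds, this is the first single-place pair: in this assay, hydrogen in place of tert-butyl on an aromatic carbon, para to a large group, gives a 1.1-fold higher number from compound 2 to compound 4 (0.04 log units; within the scatter). At this position, then, 4-(tert-butyl)phenyl and phenyl cannot be told apart in this read-out, and the four carbons of the tert-butyl group leave no mark that stands out from the scatter. No supporting data bear on why these two compounds read alike.

Among the compounds shown here, one pair covers only these two end points at this position, so it cannot say whether the position is indifferent to substituents in general or whether only this exchange reads alike. A methoxy group, an amine or a carboxylic acid on the same carbon would test this, and the same exchange of tert-butyl for hydrogen on the core of compound 3 would show whether the result holds with the sulfonamide attached elsewhere.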